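The compounds below may be only part of what the source reports. "The series", "measured", "known", "first", "only" and "open" are said of these compounds alone.

Results so far in an ADME assay on MT4 cells (Homo sapiens) for cytotoxicity, with a stated time of 5 days (a higher number here means that more compound is tolerated, a lower number that less compound is tolerated), are these:
- Compound 1 (`CC(C)(C)C#Cc1cc(N(C(=O)[C@H]2CC[C@H](C)CC2)[C@H]2CC[C@H](Oc3ccc4nccn4n3)CC2)c(C(=O)O)s1`) gives 133 nM
- Compound 2 (`CC(C)(C)C#Cc1cc(N(C(=O)[C@H]2CC[C@H](C)CC2)[C@H]2CC[C@H](OC3CCOC3)CC2)c(C(=O)O)s1`) gives 3070 nM

Among the compounds with values here, of these two numbers, the higher belongs to compound 2, and compound 1 is its only neighbour. Compound 3 (`C[C@@H]1CC[C@@H](C(=O)N(c2cc(C#CC(C)(C)C)sc2C(=O)O)[C@H]2CC[C@H](OC3CCOC3)CC2)[C@@H](O)C1`) has not yet been measured. It carries hydroxy in place of hydrogen on a saturated ring carbon, turning 4-methylcyclohexyl into 2-hydroxy-4-methylcyclohexyl. Within the data shown here, only one measured step exists (a 23-fold higher number from compound 1 to compound 2 (1.36 log units; beyond the scatter)), and it was large, but it replaced the group on an oxygen on a saturated carbon and left the 4-methylcyclohexyl untouched. Among the measured compounds shown here, it shows how far this read-out can move, yet no measured step tests the new hydroxy. A modest rise is therefore expected, and it may stay within the scatter. The estimated change is small (a 1.5-fold higher number from compound 2 to compound 3 (0.17 log units; within the scatter)) in size. Compound 3 is expected at 4500 nM within an estimated range of 1700 nM to 12000 nM in this assay when measured.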

Compound 3, half-maximal cytotoxic concentration: 11600 nM
Estimate against measurement, compound 3: 2.6-fold (0.41 log units) below, and the stated range covers the measured number.
By their numbers in this assay, from the lowest: compound 1; then compound 2; then compound 3.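

Hydroxy in place of hydrogen on a saturated ring carbon, next to the ring atom that bears a large group, gives a 3.8-fold higher number from compound 2 to compound 3 (0.58 log units; beyond the scatter) in this assay. Within the data shown here, the only earlier step, a 23-fold higher number from compound 1 to compound 2 (1.36 log units; beyond the scatter), changed the group on the oxygen, so this is the first sign that the number also responds to a change in the 4-methylcyclohexyl, here to 2-hydroxy-4-methylcyclohexyl. No available evidence bears on what lies behind this rise.

On these data alone, whether an amine or a methoxy on that same ring carbon would shift the number in the same way remains open. As far as these compounds go, it is equally open whether hydroxy at this place would give a similar step when combined with the group on the oxygen carried by compound 1.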